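Benzamide in Place of the Urea on the Shared Core

The source may hold more compounds than are shown below. What is called first, only, known or untested is meant among the compounds shown, and "the series" means these compounds.

Compound 1 `O=C(Nc1cccc(-n2cc(-c3ccncc3)c(-c3ccc(Cl)c(O)c3)n2)c1)Nc1ccc(Cl)c(Cl)c1`, in a functional assay on A498 cells (Homo sapiens) for inhibition, read by sulforhodamine B assay, with a stated time of 48 h (on this read-out lower numbers stand for stronger inhibition of growth and higher numbers for weaker inhibition of growth), compound 1 gives 940 nM.
Compound 2 `COc1cc(-c2nn(-c3cccc(NC(=O)c4ccc(Cl)c(C(F)(F)F)c4)c3)cc2-c2ccncc2)ccc1Cl`, in this assay compound 2 gives 2700 nM.
Compound 3 `COc1cc(-c2nn(-c3cccc(NC(=O)Nc4cccc(C(F)(F)F)c4)c3)cc2-c2ccncc2)ccc1Cl`, in this assay compound 3 gives 958 nM.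

Compound 3 stands second highest of the three numbers. Its nearest neighbour is compound 1, whose number lies within the scatter of that of compound 3; the furthest is compound 2, and the change a 2.8-fold lower number from compound 2 to compound 3 (0.45 log units; beyond the scatter) is beyond the scatter.

Compound 4 `COc1cc(-c2nn(-c3cccc(NC(=O)c4ccccc4)c3)cc2-c2ccncc2)ccc1Cl` differs from compound 3 in one place: phenyl in place of (3-(trifluoromethyl)phenyl)amino on a carbonyl carbon.

Among the compounds with values here, only one measured step bears on this change, and only in part. From compound 2 to compound 3 an anilide gave way to a urea carrying a 3-(trifluoromethyl)phenyl group, and the number fell: a 2.8-fold lower number from compound 2 to compound 3 (0.45 log units; beyond the scatter). The step to compound 4 runs the other way, from urea back to an anilide, and at the same time the trifluoromethyl group is lost, leaving a bare phenyl. Within the data shown here, no measured pair shows what a plain phenyl does here. He therefore expects the number for compound 4 to rise in this assay, by roughly the size seen from compound 2 to compound 3, and so estimates for compound 4 a step of a 3.7-fold higher number from compound 3 to compound 4 (0.56 log units; beyond the scatter). His estimate for compound 4 is 3500 nM, with a range from 1200 nM to 10000 nM.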

Compound 4, concentration for 50% growth inhibition: 361 nM
For compound 4 the middle estimate is 9.7-fold (0.99 log units) above the measured one; the measured number lies below the stated range.
By their numbers in this assay, from the lowest: compound 4; then compounds 1 and 3 (each within the scatter of the next); then compound 2.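

In this assay, within the data shown here, replacing the (3-(trifluoromethyl)phenyl)amino group with a bare phenyl on the carbonyl carbon gives a 2.7-fold lower number from compound 3 to compound 4 (0.42 log units; beyond the scatter) and so moves the number down, which the earlier compounds gave no sign of. Compound 2 and compound 4 both keep the anilide link, and exchanging 4-chloro-3-(trifluoromethyl)phenyl for phenyl gives a 7.5-fold lower number from compound 2 to compound 4 (0.87 log units; beyond the scatter) as a larger move in the same direction. The anilide link therefore does not by itself go with the higher number, since compound 2 stands above compound 3 while compound 4 stands below it, and the group carried on the carbonyl carbon matters at least as much as the link.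

The compounds shown do not separate the loss of the amino link from the loss of the ring substituents, and they leave open how a urea with a plain phenyl, or a benzamide with a lone methoxy, a lone amine or a carboxylic acid on the ring, or a cyclohexyl in place of the phenyl, would read. No measurement given here accounts for the change seen with compound 4.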